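The compounds below may be only part of what the source reports. "The series", "measured", "known", "first", "only" and "open" are said of these compounds alone.

Measured so far in an ADME assay on L6 cells (Rattus norvegicus) for cytotoxicity, read by resazurin assay, with a stated time of 70 h; a lower number here means a stronger inhibitor, a higher number a weaker inhibitor:

- Compound 1 `COc1cc(OC)cc(C(=O)Oc2ccc3ncccc3c2)c1`: 200000 nM
- Compound 2 `CC1=CC(C)(C)N(Cc2ccc(C(F)(F)F)cc2)c2ccc(OCc3ccc(C(F)(F)F)cc3)cc21`: > 180000 nM (a limit, not a number)
- Compound 3 `CC(=O)Oc1ccc2c(c1)C(C)=CC(C)(C)N2Cc1ccc(C#N)cc1`: 29000 nM

Only two of these entries are true numbers. Compound 3, at 29000 nM, has the lower of them, so it is the stronger inhibitor of these cells. Compound 1 gives 200000 nM, and this gap lies beyond the usual scatter of repeated measurements. Compound 2 reports only a limit, > 180000 nM.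

Compound 4 `CC(=O)Oc1ccc2c(c1)C(C)=CC(C)(C)N2Cc1cccc(C)c1` has not yet been measured. It keeps the shared core of compound 3 and changes one group: 3-methylphenyl in place of 4-cyanophenyl on a saturated chain carbon bound to a nitrogen on an aromatic ring in a ring.

Within the data shown here, no measured pair of compounds differs in just one place, so there is no direct guide to the size of this change. The best anchor is compound 3 at 29000 nM, and no step beyond the scatter is expected in this assay. The expected step is a 1.2-fold lower number from compound 3 to compound 4 (0.06 log units; within the scatter). The estimate for compound 4 is 25000 nM, with an expected range of 9000 nM to 70000 nM.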

Compound 4, half-maximal inhibitory concentration: 28000 nM
Compound 4: middle estimate off by 1.1-fold (0.05 log units), on the low side, and the stated range covers the measured number.
By their numbers in this assay, from the lowest: compounds 4 and 3 (each within the scatter of the next); then compound 1.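

In this assay, among these compounds, this pair gives the first direct reading of a change at this position: a 1.0-fold lower number from compound 3 to compound 4 (0.02 log units; within the scatter). Replacing 4-cyanophenyl with 3-methylphenyl on the saturated chain carbon removes the nitrile and its hydrogen-bond acceptor, yet the step stays within the scatter, so in this pair the nitrile is not needed for the measured cell toxicity. Compound 2 alone carries a limit, while compound 3 and compound 4 both give true numbers, so this flat step is a real comparison rather than two readings stopped at a limit: the limit of > 180000 nM in this assay, at which 1 of the 4 values shown sits.

Going by these compounds, it remains open whether a carboxylic acid or an amine on this phenyl ring would move the number beyond the scatter. On these data alone, it is also open whether a longer chain between the ring nitrogen and the phenyl ring would do so.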